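The source may hold more compounds than are shown below. What is called first, only, known or untested is meant among the compounds shown, and "the series" means these compounds.

Measured in an ADME assay on HMEC cells (Homo sapiens) for cytotoxicity, read by MTT assay; on this read-out higher numbers stand for weaker inhibition and lower numbers for stronger inhibition:
- Compound 1 `Nc1ccccc1NC(=O)c1ccc(CNc2nc3cc(Cl)ccc3o2)cc1`: 17000 nM
- Compound 2 `Nc1ccccc1NC(=O)c1ccc(CSc2nc3ccc(NCc4cccnc4)cc3s2)cc1`: > 50000 nM

Compound 2 gives only a limit and not a number, so its place is the limit of > 50000 nM in this assay, at which 1 of the 2 values shown sits. On these data alone, its true value in this assay stays open. The next compound, compound 3 `Nc1ccccc1NC(=O)c1ccc(CSc2nc3ccccc3s2)cc1`, is not yet measured. It carries hydrogen in place of ((pyridin-3-yl)methyl)amino on an aromatic carbon.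

Among the compounds with values here, no measured step shows what this change does, so the expectation is only tentative. Within the data shown here, the only numerical value comes from compound 1, at 17000 nM, and this suggests a reading within the range of the assay is possible. A moderate move towards stronger inhibition is expected, an at least 2.5-fold lower number from compound 2 to compound 3 (0.39 log units; beyond the scatter), though compound 3 could also reach the limit. The estimate for compound 3 is 20000 nM, with an expected range of 5000 nM to 50000 nM.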

Compound 3, half-maximal inhibitory concentration: 3000 nM
Compound 3: the middle estimate sits 6.7-fold (0.82 log units) above what was measured; measured number below the stated range.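

In this assay, hydrogen in place of ((pyridin-3-yl)methyl)amino on this aromatic carbon gives an at least 16-fold lower number from compound 2 to compound 3 (1.22 log units; beyond the scatter), a large step and the first measured one at this position. It shows that what sits on this carbon matters in this assay, and that the compound carrying only hydrogen there reads clearly towards stronger inhibition. Compound 2 gives a limit and not a number, so the step fixes only a smallest size, and its full size stays unknown: the limit of > 50000 nM in this assay, at which 1 of the 3 values shown sits.

The compounds shown leave open whether the step follows from the pyridine ring, the linking amine or the group as a whole, and a plain amino group or a benzylamino group on this carbon would begin to separate these. Compound 1 differs from compound 3 in more than one place, so it adds nothing to this step.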